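The source may report more compounds than this note shows. Statements on the series, on what has been measured and on what is new or still open speak of the compounds shown alone.

Working notes on the series. Among the measured compounds shown here, compound 2 `CCCc1cnc2c(C#N)c(N3CCC(c4ccccc4)CC3)ccn12` holds the lowest of the two numbers so far: in a functional assay on CHO cells for positive allosteric modulation of metabotropic glutamate receptor 2 (Homo sapiens), read by GTPgammaS binding, with a stated time of 30 min (on this read-out lower numbers stand for an effect already at smaller amounts and higher numbers for an effect only at larger amounts of compound), compound 2 gives 155 nM, while compound 1 `CCc1cnc2c(C#N)c(N3CCC(c4ccccc4)CC3)ccn12` gives 501 nM in this assay, the only measured step being a 3.2-fold lower number from compound 1 to compound 2 (0.51 log units; beyond the scatter). Compound 3 `N#Cc1c(N2CCC(c3ccccc3)CC2)ccn2c(CC(F)(F)F)cnc12` differs from compound 2 by trifluoromethyl in place of ethyl on a saturated chain carbon bound to an aromatic carbon. For the measured compounds named here, that earlier step lengthened the chain by a methyl; here carbon is replaced by fluorine, so it bears only loosely, and no measured step covers fluorine at all. A shift in this assay of roughly a 1.9-fold higher number from compound 2 to compound 3 (0.29 log units; within the scatter) is therefore expected, with little direction to lean on. Compound 3 is estimated at 300 nM, within 100 nM to 900 nM.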

Compound 3, half-maximal effective concentration: 125 nM
Compound 3: the middle estimate sits 2.4-fold (0.38 log units) above what was measured; the range from low to high includes it.
By their numbers in this assay, from the lowest: compounds 3 and 2 (each within the scatter of the next); then compound 1.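

In this assay, fluorine is tolerated at this place: 2,2,2-trifluoroethyl in place of propyl gives a 1.2-fold lower number from compound 2 to compound 3 (0.09 log units; within the scatter) and leaves compound 3 level with compound 2. The advantage over the shorter chain of compound 1 also holds with fluorine present, as trifluoromethyl in place of methyl gives a 4.0-fold lower number from compound 1 to compound 3 (0.60 log units; beyond the scatter) and so matches the earlier chain step in direction. Nothing at hand accounts for propyl and 2,2,2-trifluoroethyl reading alike. Still open, on these data alone, is how a longer chain, an amine or a carboxylic acid would read at this place. Also open, as far as these compounds go, is whether fewer fluorine atoms on the same chain would read the same.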